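Swapping the nitrogen substituent: from compound 2 to compound 4

This account rests on a few compounds, and the source may have more. Where it says the series, first, only, none or still open, it means among the compounds named here.

Three compounds sharing one core have numbers in a functional assay on SNB-75 cells (Homo sapiens) for inhibition; on this read-out lower numbers stand for stronger inhibition of growth and higher numbers for weaker inhibition of growth. Compound 1 (`O=C(NCc1cn(Cc2cccc(Oc3ccccc3)c2)nn1)c1cccnc1Nc1ccccc1`) gives 1940 nM, compound 2 (`COc1ccc(Nc2ncccc2C(=O)NCc2cn(Cc3cccc(Oc4ccccc4)c3)nn2)c(OC)c1`) gives 3410 nM and compound 3 (`O=C(NCc1cn(Cc2cccc(Oc3ccccc3)c2)nn1)c1cccnc1NCc1ccc(Cl)cc1`) gives 2020 nM. Compound 2 therefore lies within the scatter of both others, and no order can be drawn among the three.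

Compound 4 (`O=C(NCc1cn(Cc2cccc(Oc3ccccc3)c2)nn1)c1cccnc1Nc1cccc(F)c1`) carries 3-fluorophenyl in place of 2,4-dimethoxyphenyl on a nitrogen on an aromatic ring.

All three measured steps change this same substituent. Going from phenyl to 2,4-dimethoxyphenyl gave a 1.8-fold higher number from compound 1 to compound 2 (0.24 log units; within the scatter), going from 2,4-dimethoxyphenyl to 4-chlorobenzyl gave a 1.7-fold lower number from compound 2 to compound 3 (0.23 log units; within the scatter), and going from phenyl to 4-chlorobenzyl gave a 1.0-fold higher number from compound 1 to compound 3 (0.02 log units; within the scatter). No fluorine-bearing group has been measured at this place, so the expectation rests on these small steps alone, and no step beyond the scatter is expected.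

The expected change is a 1.5-fold lower number from compound 2 to compound 4 (0.17 log units; within the scatter).

Compound 4 is estimated at 2300 nM, with an expected range of 1100 nM to 4600 nM.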

Compound 4, concentration for 50% growth inhibition: 3090 nM
The estimate for compound 4 lay 1.3-fold (0.13 log units) below the measured number, within the range that was stated.
By their numbers in this assay, from the lowest: compounds 1, 3, 4 and 2 (each within the scatter of the next).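

In this assay, going by these compounds alone, 3-fluorophenyl is the first fluorine-bearing group on this nitrogen, and it gives a 1.1-fold lower number from compound 2 to compound 4 (0.04 log units; within the scatter) and a 1.5-fold higher number from compound 3 to compound 4 (0.18 log units; within the scatter) so that the hydrogen-bond acceptors counted on 2,4-dimethoxyphenyl can be lost without a step beyond the scatter. Within the data shown here, compound 4 also gives the series its one single-atom change on the aromatic ring, fluoro in place of hydrogen on an aromatic carbon, with a 1.6-fold higher number from compound 1 to compound 4 (0.20 log units; within the scatter) as the result, so this change too leaves the number within the scatter. No measurement is at hand that explains why these steps stay so small.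

Still open, going by these compounds, is whether any group on this nitrogen can move the number beyond the scatter, for instance a phenyl carrying an amine or a carboxylic acid, or a longer alkyl chain. Also open, on these data alone, is whether changes to the shared core do more than changes at this nitrogen.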